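The source may report more compounds than this note shows. Statements on the series, on what has been measured and on what is new or still open speak of the compounds shown alone.

Working notes on a set of three compounds sharing one core, all run in a functional assay on Daoy cells (Homo sapiens) for cytotoxicity, read by MTT assay, with a stated time of 72 h; a lower number here means a stronger inhibitor, a higher number a weaker inhibitor. Compound 1 `COc1cc(N(C)C(=O)N(C)c2ccc(F)cc2)cc(OC)c1OC` gives in this assay >= 125000 nM; this is a limit of the assay, not a number. Compound 2 `COc1cc(NC(=O)c2cccc([N+](=O)[O-])c2)cc(OC)c1OC` likewise returns in this assay >= 125000 nM, again only a limit. Compound 3 `COc1cc(N(C)C(=O)c2cccc(F)c2)cc(OC)c1OC` sits at >= 125000 nM in this assay, once more a limit rather than a measured number. Where compound 3 stands is thus fixed only from one side: all three values rest on the same boundary, (the limit of >= 125000 nM in this assay, at which 3 of the 3 values shown sit), and nothing among the measured compounds separates one from another. Within the data shown here, no pair differing in a single place has been measured, so no step size is known from the data.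

Compound 4 `COc1cc(N(C)C(=O)c2ccc(F)cc2)cc(OC)c1OC` is the compound not yet measured. Its difference from compound 3 is counted as 4-fluorophenyl in place of 3-fluorophenyl on a carbonyl carbon, in words 4-fluorophenyl in place of 3-fluorophenyl on a carbonyl carbon. The three measured compounds differ from each other in more than this one place and all sit at the limit, so for the step of a number no higher from compound 3 to compound 4 (the limit leaves the size open) no movement beyond the scatter is expected in either direction. The expectation for compound 4 in this assay is 125000 nM, within 60000 nM to 250000 nM, with a further limit rather than a number the most likely outcome.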

Compound 4, half-maximal inhibitory concentration: >= 125000 nM
Compound 4: no number, only a limit (the forecaster's own chance of this, stated with the estimate: 85%); the middle value lies on the limit itself.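

In this assay compound 4 gives >= 125000 nM as a limit and not a number. No step can be read between compound 3 and compound 4, because both rest on the same boundary: the limit of >= 125000 nM in this assay, at which 4 of the 4 values shown sit.

The compounds shown leave open how 4-fluorophenyl and 3-fluorophenyl on the carbonyl carbon compare, and whether any compound on the shared core has a readable value in this assay at all.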